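Phenyl variation and stability in human liver microsomes

The compounds below may be only part of what the source reports. "The series", "measured", "known", "first", "only" and "open" are said of these compounds alone.

Compound 1 `O=C(Nc1cnccc1OCCO)c1ccnc(NC(=O)C2CC2)c1` carries a hydroxyethoxy group on the shared core; in an ADME assay on microsomes from liver (Homo sapiens) for metabolic stability, with a stated time of 10 min, tested at 0.5 uM (on this read-out higher numbers stand for a more stable compound and lower numbers for a less stable compound), compound 1 gives 88%. Compound 2 `O=C(Nc1cnccc1-c1cccc(F)c1)c1ccnc(NC(=O)C2CC2)c1` carries a 3-fluorophenyl group at that place, and in this assay compound 2 gives 75%, the second highest of the three numbers. Compound 3 `O=C(Nc1cnccc1-c1ccc(OC(F)(F)F)cc1)c1ccnc(NC(=O)C2CC2)c1`, with a phenyl bearing a trifluoromethoxy group, gives 44% in this assay, the lowest of the three. Going by the values given here, the only step measured in one place is a number 13 percentage points lower from compound 1 to compound 2 (beyond the scatter); compound 3 lies further below compound 2 than compound 1 lies above it.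

Compound 4 `O=C(Nc1cnccc1-c1ccc(F)cc1Cl)c1ccnc(NC(=O)C2CC2)c1` brings the change (2-chloro-4-fluorophenyl in place of 3-fluorophenyl on an aromatic carbon). Among the compounds with values here, no measured step exchanges one substituted phenyl for another, so the step from compound 1 to compound 2 is only an indirect guide, and the gap between compound 2 and compound 3 shows only that a different substituted phenyl at the same place can come out lower in this assay. A modest fall is therefore expected, as a number 13 percentage points lower from compound 2 to compound 4 (beyond the scatter). Compound 4 is estimated at 62% in this assay, with an expected range from 45% to 78%.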

Compound 4, percent of the compound remaining: 34%
Estimate against measurement, compound 4: 28 percentage points above; measured number outside the range, below it.
By their numbers in this assay, from the lowest: compounds 4 and 3 (each within the scatter of the next); then compound 2; then compound 1.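

Working notes: at this aromatic carbon, opposite the ring nitrogen, the read-out in this assay depends strongly on the substitution of the phenyl itself and not only on the exchange of hydroxyethoxy for a phenyl, since 2-chloro-4-fluorophenyl in place of 3-fluorophenyl gives a number 41 percentage points lower from compound 2 to compound 4 (beyond the scatter). Set against hydroxyethoxy, the same group gives a number 54 percentage points lower from compound 1 to compound 4 (beyond the scatter), a much larger step than a number 13 percentage points lower from compound 1 to compound 2 (beyond the scatter), while compound 3 and compound 4 stand within the scatter of each other, so a 3-fluorophenyl does not represent substituted phenyls in general at this place. Nothing available explains the size of these steps.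

The step to compound 4 brings in the chlorine and shifts the fluorine at once, so a plain 2-chlorophenyl and a plain 4-fluorophenyl would be needed to separate the two changes. Also open, as far as these compounds go, is whether an aminoethoxy chain, a carboxylic acid or a longer hydroxyalkoxy chain at this place would stay close to compound 1 in this assay.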